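The source may report more compounds than this note shows. Statements on the series, on what has been measured and on what is new or still open speak of the compounds shown alone.

Measured so far in a functional assay (mast cells) for inhibition, with Rattus norvegicus as the target; a higher number here means that more compound is needed for the effect, a lower number that less compound is needed:
- compound 1 `CC1CCC(=NNc2ccccc2)c2ncc(C(=O)O)c(=O)n21`: 2200 nM
- compound 2 `CC1CC/C(=N\Nc2ccc(O)cc2)c2ncc(C(=O)O)c(=O)n21`: 1300 nM
- compound 3 `CC1CC/C(=N\Nc2ccc([N+](=O)[O-])cc2)c2ncc(C(=O)O)c(=O)n21`: 8900 nM

Compound 3 carries the highest number of the three, and both other compounds lie lower by more than the scatter. The next compound to consider is compound 4 `CC1CC/C(=N\Nc2ccc(C3CC3)cc2)c2ncc(C(=O)O)c(=O)n21`, with cyclopropyl in place of nitro on an aromatic carbon.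

One measured step changes the same place: a 6.8-fold higher number from compound 2 to compound 3 (0.84 log units; beyond the scatter). It is a modest step, beyond the scatter, and it involves nitro in place of hydroxy. Compound 1, with no group at that place, shows 2200 nM, also a lower number than that of compound 3. For the measured compounds named here, both comparisons therefore point the same way on leaving nitro, but no measured compound carries cyclopropyl, so neither shows how that group itself will read.

In this assay, a modest step to a lower number is expected, no larger than the measured one, and a result within the scatter of compound 3 remains possible. For compound 4 the estimated value is 3000 nM, with an expected range from 1000 nM to 8000 nM. The estimate means an expected 3.0-fold lower number from compound 3 to compound 4 (0.47 log units; beyond the scatter).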

Compound 4, half-maximal effective concentration: 1000 nM
Compound 4: middle estimate off by 3.0-fold (0.48 log units), on the high side; low and high end bracket the measured number.
By their numbers in this assay, from the lowest: compounds 4, 2 and 1 (each within the scatter of the next, the first and the last beyond it); then compound 3.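

In this assay, cyclopropyl in place of nitro on the aromatic carbon gives an 8.9-fold lower number from compound 3 to compound 4 (0.95 log units; beyond the scatter), so a group of three carbon atoms in a ring, with the same count of heavy atoms as nitro, is accepted at this position without the penalty seen for nitro. Cyclopropyl and hydroxy cannot be told apart, as a 1.3-fold lower number from compound 2 to compound 4 (0.11 log units; within the scatter) shows, which means that two quite different groups read alike here and, among the four compounds, nitro alone stands apart at the high end. No measurement on these compounds explains why nitro reads differently from the other groups.

Going by these compounds, an amine, a carboxylic acid or a longer alkyl chain on this aromatic carbon remains open, and with it whether any group can bring the number clearly below those of compound 2 and compound 4. All substituted compounds shown carry their group at this one place, so it is also open whether cyclopropyl or hydroxy would read the same elsewhere on the aromatic ring.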